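Sulfonamide Aryl Swap Against Colon Cell Viability

The source may hold more compounds than are shown below. What is called first, only, known or untested is meant among the compounds shown, and "the series" means these compounds.

Compound 1 `CC1CCN(C2CCN(S(=O)(=O)c3cn(C)cn3)CC2)CC1` was tested in an ADME assay on HCT-116 cells (Homo sapiens) for cytotoxicity, read by CellTiter-Glo, with a stated time of 72 h (a higher number here means a weaker inhibitor, a lower number a stronger inhibitor), and gave > 10000 nM, which is a limit of the assay rather than a number. Compound 2 `CC1CCN(C2CCN(S(=O)(=O)c3cc(F)c(Br)c(F)c3)CC2)CC1` likewise reached only a limit, > 5000 nM. Compound 3 `Cc1cc(C)c(S(=O)(=O)N2CCC(N3CCC(Cc4ccc(F)cc4)CC3)CC2)c(C)c1` also stopped at a limit, > 5000 nM. So compound 1 stands among limits only, as shown by the limit of > 10000 nM in this assay, at which 1 of the 3 values shown sits, and by the limit of > 5000 nM in this assay, at which 2 of the 3 values shown sit. Compound 4 `CC1CCN(C2CCN(S(=O)(=O)c3ccc(Cl)nc3)CC2)CC1` differs from compound 1 in one place: 6-chloropyridin-3-yl in place of 1-methyl-1H-imidazol-4-yl on a sulfonyl sulfur. Going by the values given here, no measured step exists between these compounds, so the change from compound 1 to compound 4 is expected to move this assay by no more than the scatter, a step that the limit leaves unreadable from compound 1 to compound 4. Compound 4 is therefore estimated at 20000 nM, within 5000 nM to 80000 nM.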

Compound 4, half-maximal inhibitory concentration: > 10000 nM
Compound 4 was reported as a limit; the forecaster's own chance of this, stated with the estimate: 85%; the middle value lies beyond the limit too.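

Compound 1 and compound 4 both stop at a limit in this assay, so no step can be read between them. The compounds shown leave open whether changing the group on the sulfonyl sulfur moves this read-out at all.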